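Methyl branching on the propargylic linker of the series

The source may report more compounds than this note shows. Statements on the series, on what has been measured and on what is new or still open speak of the compounds shown alone.

Compound 1 `Cc1cccc(C#CCNc2cccc(Cl)c2)n1` gives 174 nM in a functional assay for inhibition of metabotropic glutamate receptor 5 (Homo sapiens), read by FLIPR and calcium flux; a higher number here means a weaker inhibitor, a lower number a stronger inhibitor. Compound 2 `Cc1cccc(C#CC(C)Nc2cccc(Cl)c2)n1` carries the change methyl in place of hydrogen on a saturated chain carbon bound to a nitrogen on an aromatic ring and a triple-bonded carbon and gives 709 nM in this assay, so the step of a 4.1-fold higher number from compound 1 to compound 2 (0.61 log units; beyond the scatter) counts as a weakening. Compound 3 `CCC(C#Cc1cccc(C)n1)Sc1cccc(Cl)c1` is built on a different core; the difference between the two cores is not broken down here. In this assay compound 3 gives 862 nM, which lies within the scatter of compound 2.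

Compound 4 `Cc1cccc(C#CC(Sc2cccc(Cl)c2)C(C)C)n1` is not yet measured. Relative to compound 3 it carries methyl in place of hydrogen on a saturated chain carbon bound to two saturated chain carbons. Among the compounds with values here, this is the same kind of change as the one from compound 1 to compound 2, not the same: there the methyl entered on a saturated chain carbon bound to a nitrogen on an aromatic ring and a triple-bonded carbon, here it enters on a saturated chain carbon bound to two saturated chain carbons, one bond further out from the triple-bonded carbon. Within the data shown here, the only precedent in the set is the weakening step a 4.1-fold higher number from compound 1 to compound 2 (0.61 log units; beyond the scatter), which gives the direction but is read with caution given the different surroundings. A smaller weakening step is therefore expected for a 1.7-fold higher number from compound 3 to compound 4 (0.24 log units; within the scatter), resting on that single precedent and on compound 3 standing at 862 nM. Compound 4 is estimated at 1500 nM in this assay, with an expected range from 600 nM to 4000 nM.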

Compound 4, half-maximal inhibitory concentration: 461 nM
For compound 4 the middle estimate is 3.3-fold (0.51 log units) above the measured one; the whole stated range lies above it.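

In this assay, the effect of methyl in place of hydrogen does not carry over from the core of compound 1 to the core of compound 3, and the two steps differ: the same change on two cores in this assay, a 4.1-fold higher number (0.61 log units; beyond the scatter) from compound 1 to compound 2 and a 1.9-fold lower number (0.27 log units; within the scatter) from compound 3 to compound 4, 7.6-fold (0.88 log units) apart, beyond the scatter of two such steps. The new step, a 1.9-fold lower number from compound 3 to compound 4 (0.27 log units; within the scatter), shows no readable effect of the ethyl to isopropyl change on the core of compound 3, so the weakening seen on the core of compound 1 cannot be assumed for this change on another core. Within the data shown here, this does not show that the core alone sets the outcome, since the methyl also enters at a different place in each pair: on a saturated chain carbon bound to a nitrogen on an aromatic ring and a triple-bonded carbon in one, and on a saturated chain carbon bound to two saturated chain carbons in the other, with only one pair for each.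

The compounds shown leave open whether ethyl to isopropyl on the core of compound 1 would behave as it does on the core of compound 3, which would separate the role of the core from that of the place. They also leave open whether a longer chain such as n-butyl, or a cyclopropyl group, in place of the isopropyl of compound 4 would give a step beyond the scatter.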